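The compounds below may be only part of what the source reports. "The series", "measured", "known", "first", "only" and "open" are said of these compounds alone.

Series notes. Compound 2 `COc1cc(-c2cc(/C=C/C(=O)c3ccc(N)cc3)[nH]n2)cc(OC)c1OC` gives 3340 nM in a functional assay on COLO 205 cells (Homo sapiens) for inhibition, read by sulforhodamine B assay, with a stated time of 48 h; on this read-out lower numbers stand for stronger inhibition of growth and higher numbers for weaker inhibition of growth; compound 1 `COc1ccc(-c2cc(/C=C/C(=O)c3ccc(N)cc3)[nH]n2)cc1` gives 3450 nM and compound 3 `COc1cc(-c2cc(/C=C/C(=O)c3ccc(F)c(F)c3)[nH]n2)cc(OC)c1OC` gives 3190 nM, so the three numbers lie within the scatter of one another and compound 2 cannot be ranked against either. Among the compounds with values here, the only single-site step, a 1.0-fold lower number from compound 2 to compound 3 (0.02 log units; within the scatter), concerns the group on the carbonyl carbon and leaves the methoxy-bearing six-membered aromatic ring untouched. Compound 4 `COc1ccc(-c2cc(/C=C/C(=O)c3ccc(N)cc3)[nH]n2)cc1OC` differs from compound 2 by hydrogen in place of methoxy on an aromatic carbon. Within the data shown here, no measured step removes a methoxy group from that ring, and compound 1 and compound 2, which differ there, sit within the scatter of each other. Compound 4 is therefore expected to stay close to compound 2, with a 1.0-fold higher number from compound 2 to compound 4 (0.01 log units; within the scatter) expected within the scatter. The estimate for compound 4 is 3400 nM, ranging from 1700 nM to 6800 nM.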

Compound 4, concentration for total growth inhibition: 3590 nM
Beside the measured number, compound 4's estimate is 1.1-fold (0.02 log units) below it; the measured number falls inside the stated range.
By their numbers in this assay, from the lowest: compounds 3, 2, 1 and 4 (each within the scatter of the next).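

Hydrogen in place of methoxy on this aromatic carbon gives a 1.1-fold higher number from compound 2 to compound 4 (0.03 log units; within the scatter) in this assay, so compound 2 and compound 4 cannot be told apart at this position. Methoxy in place of hydrogen on an aromatic carbon of the same ring gives a 1.0-fold higher number from compound 1 to compound 4 (0.02 log units; within the scatter), so each single methoxy change linking compound 1, compound 2 and compound 4 now reads as flat, which the two-place difference between compound 1 and compound 2 could not show. Nothing available explains this flatness. Open, on these data alone, is whether an amine, a hydroxy group or a longer chain such as ethoxy on this carbon would also stay within the scatter.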